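The compounds below may be only part of what the source reports. "The series", "measured", "known", "first", "only" and "open" are said of these compounds alone.

Measured so far in a functional assay on PC-3 cells (Homo sapiens) for antiproliferative activity, read by MTT assay, with a stated time of 48 h; a higher number here means a weaker inhibitor, a lower number a stronger inhibitor:
compound 1 `COc1ccc(CN(C(=O)CSc2nc3ccccc3s2)c2cc(OC)c(OC)c(OC)c2)cc1O`: 2110 nM
compound 2 `COc1ccc(CN(C(=O)CSc2nc3ccccc3s2)c2cc(OC)c(OC)c(OC)c2)cc1N`: 7510 nM
compound 3 `COc1ccc(CN(C(=O)CSc2nc3ccccc3s2)c2cc(OC)c(OC)c(OC)c2)cc1[N+](=O)[O-]`: 26500 nM

Compound 3 holds the highest of the three numbers. Its nearest neighbour is compound 2, a 3.5-fold higher number from compound 2 to compound 3 (0.55 log units; beyond the scatter); the furthest is compound 1, a 13-fold higher number from compound 1 to compound 3 (1.10 log units; beyond the scatter). The remaining step, a 3.6-fold higher number from compound 1 to compound 2 (0.55 log units; beyond the scatter), completes the picture: all three changes sit on the same aromatic carbon and all three lie beyond the scatter.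

Compound 4 `COc1ccc(CN(C(=O)CSc2nc3ccccc3s2)c2cc(OC)c(OC)c(OC)c2)cc1Br` is the next step from compound 3: bromo in place of nitro on an aromatic carbon.

For the measured compounds named here, no measured step involves a bromo group, so there is no direct precedent. What the three steps do show is that nitro gave the highest number of the three groups tried at this position, and that exchanging that group has moved the number each time. Because compound 3 gives 26500 nM, the highest of the series, a move back toward the range of compound 2 is expected, that is a step of a 4.8-fold lower number from compound 3 to compound 4 (0.68 log units; beyond the scatter). Compound 4 is therefore estimated at 5500 nM in this assay, with a range of 1800 nM to 17000 nM.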

Compound 4, half-maximal inhibitory concentration: 16000 nM
Beside the measured number, compound 4's estimate is 2.9-fold (0.46 log units) below it; low and high end bracket the measured number.
By their numbers in this assay, from the lowest: compound 1; then compound 2; then compounds 4 and 3 (each within the scatter of the next).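

In this assay, bromo and nitro on this aromatic carbon cannot be told apart (a 1.7-fold lower number from compound 3 to compound 4 (0.22 log units; within the scatter)), so the high numbers at this position are not particular to nitro. Amino and hydroxy both stay clear of bromo (a 2.1-fold higher number from compound 2 to compound 4 (0.33 log units; beyond the scatter); a 7.6-fold higher number from compound 1 to compound 4 (0.88 log units; beyond the scatter)), and the series now divides into hydroxy, then amino, then the bromo and nitro pair. Nothing available explains these differences.

Going by these compounds, whether chloro, methyl or a carboxylic acid on this carbon would group with bromo and nitro, or move toward amino and hydroxy, remains open. Equally open, on these data alone, is whether the hydroxy result holds with ethoxy in place of the methoxy group on the same ring.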